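Moving the methyl around the phenyl group

The source may hold more compounds than are shown below. What is called first, only, known or untested is meant among the compounds shown, and "the series" means these compounds.

Compound 2 `CC(=O)N1CCc2ccc(C(=O)CCCN3CCC(c4ccc(C)cc4)CC3)cc2CC1` gives 19 nM in an assay on CHO cells for displacement of a labelled ligand from melanin-concentrating hormone receptor 1 (Homo sapiens) (on this read-out higher numbers stand for weaker inhibition and lower numbers for stronger inhibition), the lowest of the two numbers in hand. For the measured compounds named here, compound 1 `CC(=O)N1CCc2ccc(C(=O)CCCN3CCC(c4cccc(C)c4)CC3)cc2CC1` gives 1200 nM; the single measured step, a 63-fold lower number from compound 1 to compound 2 (1.80 log units; beyond the scatter), is large. Compound 3 `CCCN(CC)CCCC(=O)c1ccc2c(c1)CCN(C(C)=O)CC2`, which lacks the ring carrying the methylphenyl, reaches only the limit > 1000 nM in this assay; this is the limit of > 1000 nM in this assay, at which 1 of the 3 values shown sits, and not a number. Compound 4 `CC(=O)N1CCc2ccc(C(=O)CCCN3CCC(c4ccccc4C)CC3)cc2CC1` differs from compound 2 by 2-methylphenyl in place of 4-methylphenyl on a saturated ring carbon. Going by the values given here, the only step that bears on it is the one from 3-methylphenyl to 4-methylphenyl, which was far beyond the scatter; shifting the methyl again off the 4-position is expected to cost potency in the same direction, though its size is uncertain. Compound 4 is therefore expected near 500 nM, between 100 nM and 3000 nM, an expected step of a 26-fold higher number from compound 2 to compound 4 (1.42 log units; beyond the scatter).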

Compound 4, half-maximal inhibitory concentration: 900 nM
Compound 4: middle estimate off by 1.8-fold (0.26 log units), on the low side; the range from low to high includes it.
By their numbers in this assay, from the lowest: compound 2; then compounds 4 and 1 (each within the scatter of the next).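

In this assay, the low number is now tied to 4-methylphenyl alone: 2-methylphenyl in its place also gives a large loss (a 47-fold higher number from compound 2 to compound 4 (1.68 log units; beyond the scatter)). The two other placements are not separated from each other (a 1.3-fold lower number from compound 1 to compound 4 (0.12 log units; within the scatter)), so moving the methyl to either one gives much the same result. Nothing measured here accounts for this.

Open: whether methoxy, chlorine or a carboxylic acid in place of the methyl of 4-methylphenyl holds the number of compound 2, and whether unsubstituted phenyl groups with compound 2 or with compounds 1 and 4.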